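Swapping the Pyridine Arm for Plain Phenyl

This account rests on a few compounds, and the source may have more. Where it says the series, first, only, none or still open, it means among the compounds named here.

Measured so far:
Compound 1 `Cc1ncccc1C#Cc1cc(Cl)ccc1OCC(=O)O`: 143 nM
Compound 2 `CCCS(=O)(=O)c1ccc(F)c(C#Cc2cc(Cl)ccc2OCC(=O)O)c1`: 3.4 nM
Compound 3 `CN(C)S(=O)(=O)c1cncc(C#Cc2cc(Cl)ccc2OCC(=O)O)c1`: 37 nM

All three share one core, an aryl acetic acid carrying a chlorine and an alkyne that links to a second aromatic ring, and all were tested in an assay on CHO cells for displacement of a labelled ligand from prostaglandin D2 receptor 2 (Homo sapiens), read by scintillation counting; on this read-out higher numbers stand for weaker inhibition and lower numbers for stronger inhibition. Among these three numbers compound 1 stands highest, so it is the weakest binder of the set; compound 3 sits nearest to it, a gap beyond the scatter, and compound 2 lies furthest away, far beyond the scatter. Both stronger compounds carry a sulfonyl group on the second ring, which compound 1 lacks.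

Compound 4 `O=C(O)COc1ccc(Cl)cc1C#Cc1ccccc1` has not yet been measured. It differs from compound 1 in one place: phenyl in place of 2-methylpyridin-3-yl on a triple-bonded carbon. The change removes the only hydrogen-bond acceptor and the methyl from that ring, leaving a bare carbon ring at the end of the alkyne.

Going by the values given here, nothing among the measured compounds shows this exact change, so the expectation rests on the general picture: the plainer the second ring, the weaker the binding seen here. In this assay a modest move toward weaker binding is expected for compound 4, likely near the edge of the scatter, as the step of a 2.1-fold higher number from compound 1 to compound 4 (0.32 log units; beyond the scatter) expresses. Compound 4 is therefore estimated at 300 nM, with a range from 80 nM to 1100 nM.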

Compound 4, inhibition constant: 108 nM
Compound 4: the middle estimate sits 2.8-fold (0.44 log units) above what was measured, within the range that was stated.
By their numbers in this assay, from the lowest: compound 2; then compound 3; then compounds 4 and 1 (each within the scatter of the next).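

In this assay the exchange of 2-methylpyridin-3-yl for phenyl on a triple-bonded carbon comes out as a 1.3-fold lower number from compound 1 to compound 4 (0.12 log units; within the scatter), so compound 1 and compound 4 cannot be told apart on this read-out. This is the first pair among the compounds shown that differs in one place only, and it shows that the ring nitrogen, the methyl and the single hydrogen-bond acceptor of 2-methylpyridin-3-yl can all leave together with no step that rises above the scatter. No other measurement bears on this result, so the pair gives the size of the step and no explanation for it.

Going by these compounds, the nitrogen and the methyl leave together in this pair, so their separate contributions stay unknown, and a plain pyridin-3-yl or a phenyl carrying only a methyl would be needed to separate them. On these data alone, it also remains open whether a small group such as an amine or a methoxy on the phenyl of compound 4 would move the number beyond the scatter.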